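The source may report more compounds than this note shows. Statements on the series, on what has been measured and on what is new or still open speak of the compounds shown alone.

Of the compounds shown here, two of this small set have been measured for how strongly they slow the growth of a drug-resistant cancer cell line. In a functional assay on NCI/ADR cells (Homo sapiens) for inhibition, read by sulforhodamine B assay, with a stated time of 48 h (a lower number here means a stronger inhibitor of growth, a higher number a weaker inhibitor of growth), compound 1 `COc1ccc(/C=C/C2CC(=O)C=CO2)cc1OC` gives 146 uM. Compound 2 `O=c1ccoc(/C=C/c2ccccc2)c1`, which carries no substituent on its benzene ring, gives 514 uM in this assay, the highest of the two numbers and so the weaker growth inhibitor of the pair; its nearest neighbour is compound 1, whose number is lower by a margin beyond the usual scatter. Compound 3 `COc1ccc(/C=C/c2cc(=O)cco2)cc1` has not yet been measured. It arises from compound 2 by one change: methoxy in place of hydrogen on an aromatic carbon. Going by the values given here, no measured pair in this set differs by exactly this change, so the size of the step can only be estimated. Because compound 1 gives 146 uM and compound 2 gives 514 uM, and compound 1 carries methoxy groups though on a different core, a modest move towards stronger inhibition is expected rather than none. The expected step is a 1.8-fold lower number from compound 2 to compound 3 (0.26 log units; within the scatter). Compound 3 is therefore expected to give 280 uM, within a range from 110 uM to 700 uM.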

Compound 3, concentration for growth inhibition (reported as GI): 310 uM
Estimate against measurement, compound 3: 1.1-fold (0.04 log units) below, within the range that was stated.
By their numbers in this assay, from the lowest: compound 1; then compounds 3 and 2 (each within the scatter of the next).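

The replacement of hydrogen by methoxy on an aromatic carbon of a six-membered aromatic ring of carbon only, para to a group of 9 heavy atoms, now has a measured size: in this assay it gives a 1.7-fold lower number from compound 2 to compound 3 (0.22 log units; within the scatter) for this one change. Since that step lies within the scatter, this single pair gives no firm sign that methoxy at this position alters growth inhibition, although a small effect hidden by the scatter cannot be ruled out. Nothing measured on these compounds offers an explanation for the size of the step.

The compounds shown leave open what an amine or a carboxylic acid would do at this same place, and whether a longer chain, such as ethoxy, would give a step beyond the scatter. They also leave open how methoxy would behave on another carbon of the same ring, and compound 1 cannot settle this, as no single change links it to compound 2 or compound 3.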